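The compounds below may be only part of what the source reports. "The series", "measured", "known", "first", "only" and "open" are said of these compounds alone.

In a functional assay on A549 cells (Homo sapiens) for cytotoxicity, read by sulforhodamine B assay, with a stated time of 48 h (on this read-out higher numbers stand for weaker inhibition and lower numbers for stronger inhibition), compound 1 `CC(=O)OC[C@H]1O[C@@H](n2cc(CN3C(=O)/C(=C\c4ccc(C)cc4)c4ccccc43)nn2)[C@H](OC(C)=O)[C@@H](OC(C)=O)[C@@H]1OC(C)=O` gives 16500 nM, while compound 2 `CC(=O)OC[C@H]1O[C@@H](n2cc(CN3C(=O)/C(=C\C=C\c4ccccc4)c4ccccc43)nn2)[C@H](OC(C)=O)[C@@H](OC(C)=O)[C@@H]1OC(C)=O` gives 58400 nM, the higher of the two numbers. Compound 3 `CC(=O)OC[C@H]1O[C@@H](n2cc(CN3C(=O)/C(=C\c4ccco4)c4ccccc43)nn2)[C@H](OC(C)=O)[C@@H](OC(C)=O)[C@@H]1OC(C)=O` carries furan-2-yl in place of 2-phenylethenyl on a double-bonded chain carbon bound to a double-bonded ring carbon. Among the measured compounds shown here, only one measured step bears on this place, a 3.5-fold higher number from compound 1 to compound 2 (0.55 log units; beyond the scatter), and it brought in 2-phenylethenyl. For the measured compounds named here, no furan-2-yl compound has been measured, so a modest move back toward lower numbers is expected, of similar or smaller size. The estimated change is a 2.1-fold lower number from compound 2 to compound 3 (0.32 log units; beyond the scatter). For compound 3 the expected value is 28000 nM, within an estimated range of 11000 nM to 65000 nM.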

Compound 3, half-maximal inhibitory concentration: 41100 nM
Compound 3: middle estimate off by 1.5-fold (0.17 log units), on the low side; the measured number falls inside the stated range.
By their numbers in this assay, from the lowest: compound 1; then compounds 3 and 2 (each within the scatter of the next).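

In this assay there is a 1.4-fold lower number from compound 2 to compound 3 (0.15 log units; within the scatter), so furan-2-yl and 2-phenylethenyl cannot be told apart at this place, even though furan-2-yl is a five-membered aromatic ring with one hydrogen-bond acceptor. Measured against 4-methylphenyl, furan-2-yl gives a 2.5-fold higher number from compound 1 to compound 3 (0.40 log units; beyond the scatter), which leaves compound 1 the strongest of the three and both other groups on the weaker side of it. Nothing at hand explains why 4-methylphenyl stands apart. Still open, from the compounds shown here alone, is how an amine, a carboxylic acid or a longer alkyl chain would read at this place.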